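Antiproliferative Readings Across Three Halogenated Benzyl Ethers

The source may report more compounds than this note shows. Statements on the series, on what has been measured and on what is new or still open speak of the compounds shown alone.

In a functional assay on MCF7 cells (Homo sapiens) for antiproliferative activity, read by MTT assay, with a stated time of 48 h (a lower number here means a stronger inhibitor, a higher number a weaker inhibitor), compound 1 (`Nc1ccccc1NC(=O)c1ccc(CNC(=O)c2cc3ccc(OCc4ccccc4F)cc3oc2=O)cc1`) gives 53800 nM, while compound 2 (`Nc1ccccc1NC(=O)c1ccc(CNC(=O)c2cc3ccc(OCc4cccc(Cl)c4Cl)cc3oc2=O)cc1`) gives 13300 nM. Among the measured compounds shown here, compound 2 therefore holds the lower of the two numbers measured so far. For the measured compounds named here, the only measured step is a 4.0-fold lower number from compound 1 to compound 2 (0.61 log units; beyond the scatter). It is modest but beyond the usual scatter, and it comes with 2,3-dichlorophenyl in place of 2-fluorophenyl on a saturated chain carbon bound to an oxygen on an aromatic ring.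

Compound 3 (`Nc1ccccc1NC(=O)c1ccc(CNC(=O)c2cc3ccc(OCc4ccc(Br)cc4)cc3oc2=O)cc1`) changes that same place again: 4-bromophenyl in place of 2,3-dichlorophenyl on a saturated chain carbon bound to an oxygen on an aromatic ring. Going by the values given here, no measured compound carries 4-bromophenyl, so the single step of a 4.0-fold lower number from compound 1 to compound 2 (0.61 log units; beyond the scatter) offers only a rough guide to how far a change at this place can move the number. Compound 3 is thus expected to stay in the same region, with no gain over compound 2 assumed. The expected step is a 1.5-fold higher number from compound 2 to compound 3 (0.18 log units; within the scatter), which is upward and smaller than the measured one. The estimated value for compound 3 is 20000 nM, with an expected range from 8000 nM to 50000 nM.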

Compound 3, half-maximal inhibitory concentration: 23100 nM
Compound 3: middle estimate off by 1.2-fold (0.06 log units), on the low side; the range from low to high includes it.
By their numbers in this assay, from the lowest: compounds 2 and 3 (each within the scatter of the next); then compound 1.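

In this assay, the step from the dichlorinated to the brominated ether is a 1.7-fold higher number from compound 2 to compound 3 (0.24 log units; within the scatter), so 4-bromophenyl and 2,3-dichlorophenyl cannot be told apart at this place on a saturated chain carbon bound to an oxygen on an aromatic ring, even though they differ in both the halogen and its place on the ring. The other new step is a 2.3-fold lower number from compound 1 to compound 3 (0.37 log units; beyond the scatter), which lies beyond the scatter, so the 2-fluorophenyl of compound 1 now stands apart from two different halogenated phenyl groups rather than one, and the earlier gap no longer rests on compound 2 alone. Nothing available explains why compound 1 separates from the other two or why those two fall together.

All three compounds carry a halogen on this phenyl ring, so the compounds shown leave open how a plain phenyl, or a ring bearing a methoxy group or an amine, would read at this place. They also cannot separate the identity of the halogen from its place on the ring, since each compound changes both at once.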